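Methyl Added to the Phenoxy Ring of Compound 2

A few compounds are considered here, and "the series" means these few. Any claim that something is new, unique, unknown or untested is made for them only; others in the source may bear on it.

Measured so far:
compound 1 `Cc1cccc(COc2ccc(-c3cc(CN4CCN(Cc5ccc(C(F)(F)F)cc5)CC4)no3)cc2)c1`: 2500 nM
compound 2 `N#Cc1cccc(COc2ccc(-c3cc(CN4CCN(Cc5ccc(C(F)(F)F)cc5)CC4)no3)cc2)c1`: 10600 nM

In a functional assay on Mahlavu cells (Homo sapiens) for antiproliferative activity, read by sulforhodamine B assay, with a stated time of 72 h (a higher number here means a weaker inhibitor, a lower number a stronger inhibitor), compound 2 gives the highest of the two numbers measured; its nearest neighbour is compound 1, and the step from compound 1 to compound 2 is a 4.2-fold higher number from compound 1 to compound 2 (0.63 log units; beyond the scatter), where cyano replaced methyl on an aromatic carbon of the benzyl ring.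

Compound 3 `Cc1cc(-c2cc(CN3CCN(Cc4ccc(C(F)(F)F)cc4)CC3)no2)ccc1OCc1cccc(C#N)c1` keeps the cyano group and differs from compound 2 by methyl in place of hydrogen on an aromatic carbon. The methyl sits on an aromatic carbon of a six-membered aromatic ring of carbon only, ortho to a (3-cyanobenzyl)oxy group and meta to a large group.

For the measured compounds named here, no measured step concerns this position; the only step known, from compound 1 to compound 2, alters a different ring. The expected step from compound 2 to compound 3 is therefore small, a 1.3-fold lower number from compound 2 to compound 3 (0.12 log units; within the scatter), likely within the scatter. Compound 3 is estimated at 8000 nM, with a range from 3000 nM to 25000 nM.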

Compound 3, half-maximal inhibitory concentration: 450 nM
The estimate for compound 3 lay 18-fold (1.25 log units) above the measured number; measured number outside the range, below it.
By their numbers in this assay, from the lowest: compound 3; then compound 1; then compound 2.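

In this assay a single added methyl, on the aromatic carbon ortho to a (3-cyanobenzyl)oxy group, gives a 24-fold lower number from compound 2 to compound 3 (1.37 log units; beyond the scatter) and so counts as a large step for one carbon. For the compounds shown here, the earlier pair showed only that changing a group on the benzyl ring shifts the number; this step shows that the ring on the other side of the ether is also sensitive, and that hydrogen on this carbon is far from the only workable choice. No measurement shown here explains this gain.

Going by these compounds, it remains open whether a chlorine, an ethyl or a methoxy group on the same carbon would do as well as methyl. On these data alone, it is also open whether this methyl would bring a similar gain in compound 1, which carries methyl in place of the cyano group.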